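A few compounds are considered here, and "the series" means these few. Any claim that something is new, unique, unknown or untested is made for them only; others in the source may bear on it.

Series notes, measured in a functional assay on MDA-MB-231 cells (Homo sapiens) for antiproliferative activity, read by sulforhodamine B assay, with a stated time of 48 h; on this read-out higher numbers stand for weaker inhibition and lower numbers for stronger inhibition:
- compound 1 `COc1cc(OC)c2sc(-c3ccc(N/C=C\C(=O)c4ccc(OC)c([N+](=O)[O-])c4)cc3)nc2c1`: 12900 nM
- compound 2 `COc1ccc(C(=O)/C=C\Nc2ccc(-c3nc4cc(OC)c(OC)c(OC)c4s3)cc2)cc1O`: 18100 nM

Only these two values are available so far. Compound 2, at 18100 nM, lies within the usual scatter of compound 1, at 12900 nM, so the two cannot be ranked in this assay.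

The next compound is compound 3 `COc1ccc(C(=O)/C=C\Nc2ccc(-c3nc4cc(OC)c(OC)c(OC)c4s3)cc2)cc1[N+](=O)[O-]`. It is compound 2 with nitro in place of hydroxy on an aromatic carbon, ortho to a methoxy group and meta to a large group: nitro in place of hydroxy on an aromatic carbon. The same difference can be read as 3-hydroxy-4-methoxyphenyl to 4-methoxy-3-nitrophenyl.

Within the data shown here, no measured pair shows what this kind of replacement does, so the expectation rests only on how closely the two known values sit together. No shift beyond the scatter is expected in either direction. The expected change is a 1.3-fold lower number from compound 2 to compound 3 (0.11 log units; within the scatter), an estimate that stays within the scatter. In this assay the expected value of compound 3 is 14000 nM, with an estimated range of 6000 nM to 32000 nM.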

Compound 3, half-maximal inhibitory concentration: 17100 nM
Estimate against measurement, compound 3: 1.2-fold (0.09 log units) below; the measured number falls inside the stated range.
By their numbers in this assay, from the lowest: compounds 1, 3 and 2 (each within the scatter of the next).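

In this assay, among these compounds, nitro in place of hydroxy on the aromatic carbon ortho to a methoxy group gives a 1.1-fold lower number from compound 2 to compound 3 (0.02 log units; within the scatter) as the first measured pair for this replacement. At this position, then, going from 3-hydroxy-4-methoxyphenyl to 4-methoxy-3-nitrophenyl loses the hydrogen-bond donor of the hydroxy group with no shift beyond the scatter. The series also gains a second single change, methoxy in place of hydrogen on an aromatic carbon, which gives a 1.3-fold higher number from compound 1 to compound 3 (0.12 log units; within the scatter) and likewise stays inside the scatter, while no supporting measurement is available to explain either result.

On these data alone, whether an amine or a carboxylic acid on this aromatic carbon would move the number beyond the scatter remains open, as does the effect of plain hydrogen there. With both steps inside the scatter, the compounds shown offer no change yet that separates one member of the series from another, so neither this position nor the methoxy change can be called sensitive or insensitive beyond these few groups.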